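Three Compounds at the Assay Limit and a Fourth Expected

This account rests on a few compounds, and the source may have more. Where it says the series, first, only, none or still open, it means among the compounds named here.

Compound 2 `Nc1nn2c(O)cc(-c3ccc(F)cc3)nc2c1[N+](=O)[O-]` is measured in a functional assay on K562 cells (Homo sapiens) for inhibition; on this read-out higher numbers stand for weaker inhibition of growth and lower numbers for stronger inhibition of growth. In this assay compound 2 gives > 50 ug/mL, which is a limit of the assay rather than a number. Compound 1 `Nc1nn2c(O)cc(-c3cc([N+](=O)[O-])c(Cl)cc3Cl)nc2c1[N+](=O)[O-]` gives > 50 ug/mL in this assay, also a limit. Compound 3 `Nc1nn2c(O)cc(CNNCCO)nc2c1[N+](=O)[O-]` gives > 50 ug/mL in this assay, again a limit. The step that the two limits leave unreadable from compound 2 to compound 3 therefore cannot be read. What the measurements show is the limit of > 50 ug/mL in this assay, at which 3 of the 3 values shown sit. Compound 4 `Nc1nn2c(O)cc(CNCCO)nc2c1[N+](=O)[O-]` differs from compound 2 by ((2-hydroxyethyl)amino)methyl in place of 4-fluorophenyl on an aromatic carbon. Because (the limit of > 50 ug/mL in this assay, at which 3 of the 3 values shown sit), no step beyond the scatter has been observed in this assay, and the estimated step that the limit leaves unreadable from compound 2 to compound 4 is expected to remain within that scatter. For compound 4 the expected value in this assay is 80 ug/mL, with a range from 40 ug/mL to 200 ug/mL, most probably reported once more as a limit.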

Compound 4, concentration for 50% growth inhibition: > 50 ug/mL
Compound 4: no number, only a limit; the forecaster's own chance of this, stated with the estimate: 85%; the middle value lies beyond the limit too.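

Compound 4 gives > 50 ug/mL in this assay, which is a limit. The steps to compound 4 from compound 2 and compound 3 therefore cannot be read. The compounds shown leave open whether any change on the shared core gives a readable number.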